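A Methoxy Group Added to the Pendant Phenyl Ring

The compounds below may be only part of what the source reports. "The series", "measured", "known", "first", "only" and "open" are said of these compounds alone.

Of the compounds shown here, three have been measured in a functional assay on MDA-MB-468 cells (Homo sapiens) for inhibition, read by sulforhodamine B assay, with a stated time of 48 h; a lower number here means a stronger inhibitor of growth, a higher number a weaker inhibitor of growth. Compound 1 `O=C(/C(=C\c1c(-c2ccccc2)[nH]c2ccccc12)S(=O)(=O)c1ccccc1)c1ccccc1` gives 4200 nM, compound 2 `COc1ccc(-c2[nH]c3ccc(OC)cc3c2/C=C(\C#N)S(=O)(=O)c2ccccc2)cc1` gives 1300 nM, and compound 3 `COc1ccc2[nH]c(-c3ccccc3)c(C=C(C#N)C#N)c2c1` gives 2100 nM. Compound 3 thus stands second highest of the three numbers, but its gap to compound 2 and its gap to compound 1 both lie within the scatter, so no order among them can be claimed. Compound 4 `COc1ccc(-c2[nH]c3ccc(OC)cc3c2C=C(C#N)C#N)cc1` has not yet been measured. It differs from compound 3 in one place: methoxy in place of hydrogen on an aromatic carbon. Among the compounds with values here, no step between measured compounds isolates this change. Compound 4 is expected to land close to compound 3, with a step of a 1.2-fold lower number from compound 3 to compound 4 (0.07 log units; within the scatter) that does not exceed the scatter. The estimate for compound 4 is 1800 nM, within 700 nM to 4500 nM.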

Compound 4, concentration for 50% growth inhibition: 503 nM
Compound 4: middle estimate off by 3.6-fold (0.55 log units), on the high side, and the stated range ends above it.
By their numbers in this assay, from the lowest: compound 4; then compounds 2, 3 and 1 (each within the scatter of the next, the first and the last beyond it).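

Methoxy in place of hydrogen, on an aromatic carbon para to a large group, gives a 4.2-fold lower number from compound 3 to compound 4 (0.62 log units; beyond the scatter) in this assay. Within the data shown here, this is the first single-place step, and it shows that this position on the phenyl ring can move the number beyond the scatter. Nothing shown here explains the step.

The compounds shown leave open whether methoxy is special at this position or whether a hydroxyl, an ethoxy group or an amine would give a similar step. They also leave open whether the step carries over to other groups on the shared core.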